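Title: A Cyanobenzyl Ether at the Saturated Ring Carbon

A few compounds are considered here, and "the series" means these few. Any claim that something is new, unique, unknown or untested is made for them only; others in the source may bear on it.

This account follows a change made to compound 1, `Cc1nn(-c2ncnc3nc[nH]c23)c2c1C(C(=O)N(C)c1nccs1)CC(=O)N2`, whose activity was measured in a functional assay on HEK293 cells for agonist activity at G-protein coupled receptor 39 (Homo sapiens), read by scintillation proximity assay and inositol phosphate accumulation, with a stated time of 75 min, in the presence of a further agent that is not named here; a lower number here means that less compound is needed, a higher number that more compound is needed for the effect. For the measured compounds named here, compound 1 gives 18 nM, which places it second highest of the three numbers known. Its nearest neighbour is compound 2, `Cc1nn(-c2ncnc3nc[nH]c23)c2c1C(C(=O)NCc1ccc(F)cc1)CC(=O)N2`, which gives 4 nM; the furthest is compound 3, `CC(C)(C)c1cc(C(=O)N/N=C/c2ccc(O)cc2O)[nH]n1`, which gives 240 nM. Going by the values given here, the only single-point step among the measured compounds is the one where (4-fluorobenzyl)amino replaces methyl(1,3-thiazol-2-yl)amino on a carbonyl carbon, giving a 4.5-fold lower number from compound 1 to compound 2 (0.65 log units; beyond the scatter).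

The new compound 4, `Cc1nn(-c2ncnc3nc[nH]c23)c2c1C(OCc1ccccc1C#N)CC(=O)N2`, differs from compound 1 as follows: (2-cyanobenzyl)oxy in place of methyl(1,3-thiazol-2-yl)carbamoyl on a saturated ring carbon. This change goes further than the measured step, since the whole methyl(1,3-thiazol-2-yl)carbamoyl leaves and (2-cyanobenzyl)oxy enters at the saturated ring carbon. Among the compounds with values here, the step from compound 1 to compound 2 shows that a benzyl-bearing group at this position is tolerated and even favoured, but no measured pair shows what the ether linkage itself does. The expectation is therefore a step of no more than modest size, a 1.7-fold higher number from compound 1 to compound 4 (0.22 log units; within the scatter), with the direction uncertain. Compound 4 is estimated at 30 nM, within a range of 8 nM to 120 nM.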

Compound 4, half-maximal effective concentration: 8 nM
Compound 4: the middle estimate sits 3.8-fold (0.57 log units) above what was measured; the range from low to high includes it.
By their numbers in this assay, from the lowest: compounds 2 and 4 (each within the scatter of the next); then compound 1; then compound 3.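

In this assay the exchange of the whole methyl(1,3-thiazol-2-yl)carbamoyl for (2-cyanobenzyl)oxy on the saturated ring carbon gives a 2.3-fold lower number from compound 1 to compound 4 (0.35 log units; beyond the scatter), so the carbonyl that compound 1 and compound 2 both carry at this place is not required for activity at this level. Compound 2 gives 4 nM and compound 4 gives 8 nM, values within the usual scatter of each other, so an amide-linked 4-fluorobenzyl group and an ether-linked 2-cyanobenzyl group cannot be told apart at this place by this measurement. No evidence is at hand on what lies behind the step.

The linkage, the aromatic ring and the substituent on it all change in this one step, and the compounds shown do not separate the part played by the ether oxygen from that of the nitrile. A plain benzyloxy group, a 4-fluorobenzyloxy group or a small methoxy group at the same saturated ring carbon would divide these contributions, and a bare hydroxyl there would show how much depends on the benzyl part at all.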